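This account rests on a few compounds, and the source may have more. Where it says the series, first, only, none or still open, it means among the compounds named here.

In an ADME assay on CHO cells (Cricetulus griseus) for inhibition, read by MTT assay (on this read-out lower numbers stand for stronger inhibition and higher numbers for weaker inhibition), compound 3 `CCN(CC)Cc1ccc(C)c(Nc2nc3ccccc3n2Cc2ccc(F)cc2)c1O` gives > 50000 nM, which is a limit and not a number. Compound 1 `CCN(CC)Cc1ccc(C)c(Nc2nc3ccccc3n2Cc2ccc(C#N)cc2)c1O` gives > 50000 nM, also a limit. Compound 2 `CCN(CC)Cc1cccc(Nc2nc3ccccc3n2Cc2ccc(C(F)(F)F)cc2)c1O`, which also carries trifluoromethyl, gives > 50000 nM, again a limit. Compound 4 `CCN(CC)Cc1ccc(C)c(Nc2nc3ccccc3n2Cc2ccc(C(F)(F)F)cc2)c1O` has trifluoromethyl in place of fluoro on an aromatic carbon of compound 3: trifluoromethyl in place of fluoro on an aromatic carbon. Within the data shown here, the one measured step that bears on this, a step that the two limits leave unreadable from compound 1 to compound 3, also swaps a group on an aromatic carbon, but it has no readable size. All the evidence so far is the limit of > 50000 nM in this assay, at which 3 of the 3 values shown sit. No clear change is therefore expected in this assay, and the estimated step is a number no higher from compound 3 to compound 4 (the limit leaves the size open). For compound 4 the expected value is 50000 nM, with an estimated range of 25000 nM to 80000 nM.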

Compound 4, half-maximal inhibitory concentration: 33900 nM
Compound 4: middle estimate off by 1.5-fold (0.17 log units), on the high side, and the stated range covers the measured number.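

this assay now gives a first number rather than only limits, so steps at this position can be given a floor: trifluoromethyl in place of fluoro gives an at least 1.4-fold lower number from compound 3 to compound 4 (0.16 log units; that floor lies within the scatter), trifluoromethyl in place of cyano gives an at least 1.4-fold lower number from compound 1 to compound 4 (0.16 log units; that floor lies within the scatter), and methyl in place of hydrogen on the other aromatic ring gives an at least 1.4-fold lower number from compound 2 to compound 4 (0.16 log units; that floor lies within the scatter). Each floor is small, so none of these steps is shown to be a real change. Most of the data still rest on one ceiling: the limit of > 50000 nM in this assay, at which 3 of the 4 values shown sit.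

On these data alone, the true size of each step stays open. So does the outcome with an amine or a carboxylic acid on this aromatic carbon.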